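Pyridin-2-yl in place of naphthalen-1-yl in the series

The compounds below may be only part of what the source reports. "The series", "measured", "known", "first", "only" and "open" are said of these compounds alone.

Values in a functional assay on A549 cells (Homo sapiens) for antiproliferative activity, read by MTT assay, with a stated time of 48 h; on this read-out higher numbers stand for weaker inhibition and lower numbers for stronger inhibition
compound 1 `Cn1cc(C2=C(c3nn(CCCN4CCCCC4)c4ncccc34)C(=O)N(c3ccc(Cl)cc3)C2=O)c2ccccc21` gives 28700 nM
compound 2 `Cn1cc(C2=C(c3nn(CCCN4CCCCC4)c4ncccc34)C(=O)N(c3cccc4ccccc34)C2=O)c2ccccc21` gives 2820 nM

Compound 2 has the lower of the two numbers in this assay. Compound 3 `Cn1cc(C2=C(c3nn(CCCN4CCCCC4)c4ncccc34)C(=O)N(c3ccccn3)C2=O)c2ccccc21` carries pyridin-2-yl in place of naphthalen-1-yl on an amide-type nitrogen in a ring. Within the data shown here, one measured step bears on this place: a 10-fold lower number from compound 1 to compound 2 (1.01 log units; beyond the scatter), a large step beyond the scatter, with naphthalen-1-yl in place of 4-chlorophenyl. Removing naphthalen-1-yl is therefore expected to give a higher number in this assay, by a step of similar or smaller size. The expected step is a 4.3-fold higher number from compound 2 to compound 3 (0.63 log units; beyond the scatter). For compound 3 the estimated value is 12000 nM, with a range of 4000 nM to 35000 nM.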

Compound 3, half-maximal inhibitory concentration: > 100000 nM
Compound 3 ended at the assay's limit; the forecaster's own chance of this, stated with the estimate: 10%; middle value at least 8.3-fold (0.92 log units) from the limit.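

In this assay the value of compound 3 is a limit, not a number: the limit of > 100000 nM in this assay, at which 1 of the 3 values shown sits.

The group on the amide-type nitrogen can therefore move the read-out further than the earlier pair showed, with an at least 35-fold higher number from compound 2 to compound 3 (1.54 log units; beyond the scatter). Pyridin-2-yl also falls behind 4-chlorophenyl, with an at least 3.4-fold higher number from compound 1 to compound 3 (0.54 log units; beyond the scatter), so the order at this place runs naphthalen-1-yl, 4-chlorophenyl, pyridin-2-yl.

Still open, from the compounds shown here alone, is whether the higher number goes with the ring nitrogen of pyridin-2-yl or with the loss of the second aromatic ring. Unsubstituted phenyl and quinolin-8-yl at this place would separate the two.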